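The source may hold more compounds than are shown below. What is called first, only, known or untested is meant among the compounds shown, and "the series" means these compounds.

In a functional assay on HL-60 cells (Homo sapiens) for cytotoxicity, read by XTT assay, with a stated time of 3 days (on this read-out higher numbers stand for weaker inhibition and lower numbers for stronger inhibition), the compounds share one core and differ in the aromatic group attached to it. Compound 1 `OC[C@H]1O[C@@H](n2cc(F)c3c(-c4ccccc4)ncnc32)[C@H](O)[C@@H]1O`, which carries phenyl, gives > 40000 nM, and this value is a limit, not a number. Compound 2 `OC[C@H]1O[C@@H](n2cc(F)c3c(-c4cccs4)ncnc32)[C@H](O)[C@@H]1O`, which carries thiophen-2-yl, gives 4300 nM. For the measured compounds named here, the one measured step is an at least 9.3-fold lower number from compound 1 to compound 2 (0.96 log units; beyond the scatter). As far as these compounds go, one end of that step is the limit of > 40000 nM in this assay, at which 1 of the 3 values shown sits, so its true size remains open.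

Compound 3 `OC[C@H]1O[C@@H](n2cc(F)c3c(-c4c[nH]cn4)ncnc32)[C@H](O)[C@@H]1O`, which carries 1H-imidazol-4-yl, has the result "not determined" (no result reported), so it gives no number from which to start. Compound 4 `OC[C@H]1O[C@@H](n2cc(F)c3c(-c4ccoc4)ncnc32)[C@H](O)[C@@H]1O` has furan-3-yl in place of 1H-imidazol-4-yl on an aromatic carbon. Going by the values given here, no measured step involves this exchange, and no size or direction can be expected in this assay for the step from compound 3. The nearest guide is the measured step to thiophen-2-yl, since furan-3-yl also has a five-membered aromatic ring. Compound 4 is therefore expected to fall near compound 2 at 4300 nM, with no difference beyond the scatter as the central expectation, although the uncertainty is wide. For compound 4, the estimated value is 2500 nM, with an expected range from 400 nM to 15000 nM.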

Compound 4, half-maximal inhibitory concentration: 2000 nM
The estimate for compound 4 lay 1.3-fold (0.10 log units) above the measured number; the measured number falls inside the stated range.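

In this assay, for the compounds shown here, this position responds to a change between two five-membered aromatic rings, which the earlier compounds could not show: furan-3-yl in place of thiophen-2-yl gives a 2.2-fold lower number from compound 2 to compound 4 (0.33 log units; beyond the scatter). The exchange alters both the hetero atom and the point of attachment, so the data do not assign the step to either alone. Measured against phenyl, furan-3-yl gives an at least 20-fold lower number from compound 1 to compound 4 (1.30 log units; beyond the scatter), so compound 2 and compound 4, both with a five-membered aromatic ring, lie on the same side of compound 1, and the true size of that step stays open: the limit of > 40000 nM in this assay, at which 1 of the 4 values shown sits.

As far as these compounds go, the steps from compound 3 cannot be read, so the place of 1H-imidazol-4-yl relative to the other groups remains unknown. Also open, from the compounds shown here alone, is whether thiophen-3-yl or furan-2-yl would separate the effect of the hetero atom from that of the attachment point, and how a pyridin-3-yl ring, an amine or a carboxylic acid would behave at this position.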